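Ethyl in place of ethoxycarbonyl on the shared core

The compounds below may be only part of what the source reports. "The series", "measured", "known", "first", "only" and "open" are said of these compounds alone.

In a physicochemical assay for lipophilicity, measured as octanol-water partition (on this read-out higher numbers stand for higher lipophilicity and lower numbers for lower lipophilicity), compound 2 (`CCOC(=O)CC[C@H](NC(=O)[C@@H]1C[C@@H](O)CN1C(=O)[C@@H](NC(C)=O)C(C)(C)C)c1ccc(-c2scnc2C)cc1`) gives 1.59 as the lower of the two numbers in hand, while compound 1 (`CC(=O)N[C@H](C(=O)N1C[C@H](O)C[C@H]1C(=O)N[C@@H](CCC(C)(C)C)c1ccc(-c2scnc2C)cc1)C(C)(C)C`) gives 3.21 as the higher. Compound 3 (`CCCC[C@H](NC(=O)[C@@H]1C[C@@H](O)CN1C(=O)[C@@H](NC(C)=O)C(C)(C)C)c1ccc(-c2scnc2C)cc1`) is still unmeasured. It carries ethyl in place of ethoxycarbonyl on a saturated chain carbon, three bonds along the chain from an amide-type nitrogen and an aromatic carbon. Within the data shown here, only one measured step bears on this place. Ethoxycarbonyl in place of tert-butyl there gave a number 1.62 log units lower from compound 1 to compound 2 (beyond the scatter) as the sole guide, a large step. The new change takes that same ethoxycarbonyl away again, so much of that step should be undone. Ethyl is not tert-butyl, however, and no measurement yet separates the two. Upward and beyond the scatter, but smaller than the measured step, the expected change is a number 1.11 log units higher from compound 2 to compound 3 (beyond the scatter) in this assay for this pair. The estimated value for compound 3 is 2.7 with an expected range from 2.3 to 3.1 on this read-out.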

Compound 3, partition coefficient: 2.75
The estimate for compound 3 lay 0.05 log units below the measured number; low and high end bracket the measured number.
By their numbers in this assay, from the lowest: compound 2; then compound 3; then compound 1.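

In this assay, ethyl in place of ethoxycarbonyl on this saturated chain carbon gave a number 1.16 log units higher from compound 2 to compound 3 (beyond the scatter) as a large step, which shows that the low number of compound 2 does not persist once ethoxycarbonyl leaves, even without tert-butyl returning. Ethyl and tert-butyl, which no earlier pair could separate, are now told apart: ethyl in place of tert-butyl gave a number 0.46 log units lower from compound 1 to compound 3 (beyond the scatter) as a modest step, smaller than the one between ethoxycarbonyl and ethyl, so the two groups without oxygen are not interchangeable here, yet they stand closer to each other than either stands to ethoxycarbonyl. Nothing available explains why these steps have the sizes they do.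

Three groups at one place do not show whether the numbers in this assay follow the size of the group, its branching or the presence of the ester, and propyl or a longer unbranched chain would be needed to separate the first two. On these data alone, how a carboxylic acid, an amide or an amine on this carbon would stand relative to ethoxycarbonyl also remains open.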